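This account rests on a few compounds, and the source may have more. Where it says the series, first, only, none or still open, it means among the compounds named here.

Compound 1 `CCCn1c(=O)[nH]c2nc(-c3ccc(S(=O)(=O)N4CCN(c5ccc(Br)cc5)CC4)cc3)[nH]c2c1=O` gives in an assay on CHO cells for displacement of a labelled ligand from adenosine receptor A3 (Homo sapiens), read by scintillation counting, with a stated time of 45 min, in the presence of a further agent that is not named here (on this read-out lower numbers stand for stronger inhibition and higher numbers for weaker inhibition), the limit > 1000 nM rather than a measured number. Compound 2 `CCCn1c(=O)[nH]c2nc(-c3ccc(S(=O)(=O)N4CCN(c5ccc(C)cc5)CC4)cc3)[nH]c2c1=O` likewise gives only the limit > 1000 nM in this assay.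

The step from compound 1 to compound 2, methyl in place of bromo on an aromatic carbon, is a step that the two limits leave unreadable from compound 1 to compound 2 because both readings sit at the limit of > 1000 nM in this assay, at which 2 of the 2 values shown sit. Compound 3 `CCCn1c(=O)[nH]c2nc(-c3ccc(S(=O)(=O)N4CCN(C(C)c5ccccc5)CC4)cc3)[nH]c2c1=O` differs from compound 2 by 1-phenylethyl in place of 4-methylphenyl on an amine nitrogen in a ring. Among the measured compounds shown here, no measured step bears on this change, and compound 2 stands only at a limit. Compound 3 is therefore expected to stay weak, most likely again at the limit, with an estimated 3000 nM (range 800 nM to 20000 nM). The step from compound 2 to compound 3 is expected to be a step that the limit leaves unreadable from compound 2 to compound 3.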

Compound 3, inhibition constant: > 1000 nM
Compound 3: a limit, no number; the forecaster's own chance of this, stated with the estimate: 75%; the middle value lies beyond the limit too.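

Compound 1, compound 2 and compound 3 each give only a limit, not a number, so no step among them can be read: the limit of > 1000 nM in this assay, at which 3 of the 3 values shown sit.

From the compounds shown here alone, how strongly any of the three inhibits, and whether the group on the ring nitrogen matters at all, stays open.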